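Thiourea series: methyl for chloro on the anilide ring

The source may hold more compounds than are shown below. What is called first, only, known or untested is meant among the compounds shown, and "the series" means these compounds.

Compound 1 `Cc1ccc(NC(=S)NC(=O)c2cn(-c3ccccc3)nc2-c2ccc(F)cc2)cc1` gives 5440 nM in a functional assay on MCF7 cells (Homo sapiens) for inhibition, read by CCK-8 assay, with a stated time of 48 h; a higher number here means a weaker inhibitor, a lower number a stronger inhibitor.
Compound 2 `Cc1ccc(NC(=S)NC(=O)c2cn(-c3ccccc3)nc2-c2ccc(Cl)cc2)cc1` gives 5980 nM in this assay.
Compound 3 `COc1ccc(-c2nn(-c3ccccc3)cc2C(=O)NC(=S)Nc2ccc(Cl)cc2)cc1` gives 4760 nM in this assay.

Compound 3 sits at the low end of the three numbers, but its gaps to compound 1 and to compound 2 both fall within the scatter, so the three compounds read alike. Going by the values given here, the only measured step, a 1.1-fold higher number from compound 1 to compound 2 (0.04 log units; within the scatter), exchanges halogens on the other aryl ring and left the number essentially unchanged.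

Compound 4 `COc1ccc(-c2nn(-c3ccccc3)cc2C(=O)NC(=S)Nc2ccc(C)cc2)cc1` differs from compound 3 by methyl in place of chloro on an aromatic carbon. Among the compounds with values here, no measured step touches this ring directly. Compound 1 and compound 2 carry the (4-methylphenyl)amino group while compound 3 carries the (4-chlorophenyl)amino group, and all three values lie within the scatter of one another, which gives no sign that this exchange moves the number.

For compound 4 the expected step is therefore a 1.1-fold higher number from compound 3 to compound 4 (0.04 log units; within the scatter), none beyond the scatter. Compound 4 is estimated at 5200 nM, with a range of 2600 nM to 10400 nM in this assay.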

Compound 4, half-maximal inhibitory concentration: 4630 nM
Compound 4: middle estimate off by 1.1-fold (0.05 log units), on the high side, within the range that was stated.
By their numbers in this assay, from the lowest: compounds 4, 3, 1 and 2 (each within the scatter of the next).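

Working notes: in this assay, the direct exchange of methyl for chloro on an aromatic carbon, para to a large group, gives the first measured step at this position (a 1.0-fold lower number from compound 3 to compound 4 (0.01 log units; within the scatter)), so 4-chlorophenyl to 4-methylphenyl leaves the number unmoved with the rest of the molecule held constant. With the 4-methylphenyl group present in all three compounds, methoxy in place of chloro on the other aryl ring (a 1.3-fold lower number from compound 2 to compound 4 (0.11 log units; within the scatter)) and methoxy in place of fluoro there (a 1.2-fold lower number from compound 1 to compound 4 (0.07 log units; within the scatter)) also stay within the scatter. No supporting measurement bears on this result.

All four compounds read alike, so the shown set defines no preference at either ring. From the compounds shown here alone, whether an amine, a carboxylic acid or a longer chain at the 4-methylphenyl position would move the number remains open.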